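A bromine swap on two inactive chalcone amides

A few compounds are considered here, and "the series" means these few. Any claim that something is new, unique, unknown or untested is made for them only; others in the source may bear on it.

Compound 1 `O=C(COc1ccc(C(=O)/C=C/c2ccc(F)c(F)c2)cc1)N[C@H]1CCOC1=O` and compound 2 `O=C(COc1ccc(C(=O)/C=C/c2cccc(F)c2)cc1)N[C@H]1CCOC1=O` share one core and differ by a single fluoro on an aromatic carbon. In a functional assay on MGC-803 cells (Homo sapiens) for antiproliferative activity, read by MTT assay, with a stated time of 72 h (on this read-out higher numbers stand for weaker inhibition and lower numbers for stronger inhibition), compound 1 gives > 64000 nM, which is a limit of the assay rather than a number. In this assay compound 2 likewise gives > 64000 nM, again a limit. The step from compound 1 to compound 2 is therefore a step that the two limits leave unreadable from compound 1 to compound 2, because both values sit at the limit of > 64000 nM in this assay, at which 2 of the 2 values shown sit, and no size can be read from it. Compound 3 `O=C(COc1ccc(C(=O)/C=C/c2ccc(Br)cc2)cc1)N[C@H]1CCOC1=O` is not yet measured; it differs from compound 2 by 4-bromophenyl in place of 3-fluorophenyl on a double-bonded chain carbon bound to a double-bonded chain carbon. Only the unreadable step from compound 1 to compound 2 bears on this change, and it gives neither size nor direction. For compound 3 a value at or near the same limit is expected, so the estimated step that the limit leaves unreadable from compound 2 to compound 3 carries no measured anchor. Compound 3 is expected to give about 70000 nM, between 25000 nM and 200000 nM.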

Compound 3, half-maximal inhibitory concentration: 51000 nM
The estimate for compound 3 lay 1.4-fold (0.14 log units) above the measured number; the range from low to high includes it.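

Compound 3 is the only one of the three with a number rather than a limit in this assay: it gives 51000 nM, so this position can yield a reading. Replacing 3-fluorophenyl with 4-bromophenyl gives an at least 1.2-fold lower number from compound 2 to compound 3 (0.09 log units; that floor lies within the scatter), and replacing 3,4-difluorophenyl in the same way gives an at least 1.2-fold lower number from compound 1 to compound 3 (0.09 log units; that floor lies within the scatter). Neither floor goes beyond the usual scatter, and the true size of both steps stays unknown because the other two compounds give only a limit: the limit of > 64000 nM in this assay, at which 2 of the 3 values shown sit.

The change swaps the halogen and its place on the ring together, so the compounds shown cannot separate the two effects; 3-bromophenyl or 4-fluorophenyl would be needed for that. On these data alone, whether a group without halogen, such as 4-methoxyphenyl or 4-aminophenyl, would give a readable number at this position also remains open.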